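The compounds below may be only part of what the source reports. "The series", "measured", "known", "first", "only" and "open" are said of these compounds alone.

In an assay on isolated protein for inhibition of Indoleamine 2,3-dioxygenase 1 (Homo sapiens), with a stated time of 30 min (a lower number here means a stronger inhibitor, a higher number a weaker inhibitor), two analogues sharing one core have been measured. Compound 1 `O=C(NCc1cnc2scc(-c3ccc(Br)cc3)n12)NC1CCCCC1` carries a cyclohexyl on the urea nitrogen and gives 1800 nM. Compound 2 `O=C(NCc1cnc2scc(-c3ccc(Br)cc3)n12)Nc1ccccc1` carries a phenyl there instead and gives 220 nM. Among the measured compounds shown here, the single measured step, an 8.2-fold lower number from compound 1 to compound 2 (0.91 log units; beyond the scatter), was modest but beyond the scatter; on these two numbers compound 2 stands as the lower of the pair, with compound 1 the only neighbour and that one at a higher value.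

Compound 3 `COc1ccc(NC(=O)NCc2cnc3scc(-c4ccc(Br)cc4)n23)cc1` remains unmeasured. It differs from compound 2 by methoxy in place of hydrogen on an aromatic carbon, placed on an aromatic carbon of a six-membered aromatic ring of carbon only, para to a large group. For the measured compounds named here, no measured step bears on a substituent of that phenyl; the only step seen, from cyclohexyl to phenyl, concerns the ring itself and not a group upon it. A change of the size of a 1.1-fold lower number from compound 2 to compound 3 (0.04 log units; within the scatter) is therefore expected, most likely no difference beyond the scatter. Compound 3 is thus estimated at 200 nM, within a range from 70 nM to 600 nM.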

Compound 3, half-maximal inhibitory concentration: 190 nM
For compound 3 the middle estimate is 1.1-fold (0.02 log units) above the measured one, within the range that was stated.
By their numbers in this assay, from the lowest: compounds 3 and 2 (each within the scatter of the next); then compound 1.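

In this assay, methoxy in place of hydrogen on an aromatic carbon, para to a large group, gives a 1.2-fold lower number from compound 2 to compound 3 (0.06 log units; within the scatter), so at this position the change from phenyl to 4-methoxyphenyl leaves the read-out within the scatter, which shows that this position of the ring can carry methoxy, with its 2 heavy atoms and hydrogen-bond acceptor, without a difference that can be told from repeat measurement. With 4-methoxyphenyl in place of cyclohexyl on the urea nitrogen, the separation from the cyclohexyl analogue holds, at a 9.5-fold lower number from compound 1 to compound 3 (0.98 log units; beyond the scatter), so the gap first seen with the plain phenyl remains beyond the scatter with methoxy on the ring. No measured information accompanies these numbers that would explain why methoxy makes no difference here.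

The compounds shown leave open whether a different group at this same place, such as a carboxylic acid, an amine or a longer alkoxy chain, would move the number beyond the scatter. They also leave open whether methoxy on another carbon of the ring would read the same as it does here.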